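The source may hold more compounds than are shown below. What is called first, only, known or untested is meant among the compounds shown, and "the series" means these compounds.

Measured compounds:
compound 1, `Cc1cc(N2C(=O)C3=C(CCCC3)C2=O)c(F)cc1NC(=O)c1occc1C` — 58 nM in a functional assay for positive allosteric modulation of metabotropic glutamate receptor 1 (Homo sapiens), read by calcium flux, in the presence of a further agent that is not named here; a lower number here means that less compound is needed, a higher number that more compound is needed for the effect
compound 2, `Cc1ccoc1C(=O)Nc1c(F)cc(N2C(=O)[C@H]3CC=CC[C@H]3C2=O)c(F)c1F` — in this assay compound 2 reaches only the limit > 10000 nM
compound 3, `Cc1ccoc1C(=O)Nc1c(F)cc(N2C(=O)C3=C(CCCC3)C2=O)c(F)c1F` — in this assay compound 3 likewise reaches only the limit > 10000 nM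

Compound 1 carries the only number shown; the other two values sit at the limit of > 10000 nM in this assay, at which 2 of the 3 values shown sit, and are limits, not numbers. Going by the values given here, no pair of measured compounds differs in one place, so no single step is known.

Compound 4, `Cc1cc(N2C(=O)C3=C(CCCC3)C2=O)c(F)cc1NC(=O)c1ccco1`, differs from compound 1 by hydrogen in place of methyl on an aromatic carbon. Among the compounds with values here, since no step in this assay is known, the step from compound 1 to compound 4 is expected to be modest and toward more compound needed, a 2.6-fold higher number from compound 1 to compound 4 (0.41 log units; beyond the scatter). Compound 4 is expected at 150 nM, within 50 nM to 600 nM.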

Compound 4, half-maximal effective concentration: > 10000 nM
Compound 4 was reported as a limit; the forecaster's own chance of this, stated with the estimate: 5%; middle value at least 66-fold (1.82 log units) away from the limit.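

Going by these compounds alone, replacing 3-methylfuran-2-yl with furan-2-yl gives the first single step, and it is large: an at least 170-fold higher number from compound 1 to compound 4 (2.23 log units; beyond the scatter). On the core of compound 1, a measurable value therefore depends on this methyl, on the carbon next to the ring atom that bears a large group. Compound 4 stands at a limit, not a number: the limit of > 10000 nM in this assay, at which 3 of the 4 values shown sit.

Going by these compounds, the full size of the step stays unknown, as only its lower bound can be read. Also open, on these data alone, is whether ethyl, chlorine or methoxy at this position would keep a measurable value.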